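The source may hold more compounds than are shown below. What is called first, only, known or untested is meant among the compounds shown, and "the series" means these compounds.

Three compounds share one core and differ only in the group attached to the carbonyl carbon of a side chain. Compound 1 `CC(C)(C)c1ccc(C(=O)N2CCC3(CC2)C(=O)N(CC(=O)N2CCCCC2CCO)CN3c2ccccc2)cc1` carries a 2-(2-hydroxyethyl)piperidin-1-yl group there, and in an assay on HEK293 cells for displacement of a labelled ligand from NPC1-like intracellular cholesterol transporter 1 (Homo sapiens) (a lower number here means a stronger inhibitor, a higher number a weaker inhibitor), compound 1 gives 6100 nM. Compound 2 `CC(C)(C)c1ccc(C(=O)N2CCC3(CC2)C(=O)N(CC(=O)NCNS(C)(=O)=O)CN3c2ccccc2)cc1` carries a ((methanesulfonamido)methyl)amino group, and in this assay compound 2 gives 3200 nM. Compound 3 `CC(C)(C)c1ccc(C(=O)N2CCC3(CC2)C(=O)N(CC(=O)NCCCCO)CN3c2ccccc2)cc1` carries a (4-hydroxybutyl)amino group, and in this assay compound 3 gives 19200 nM. Compound 3 thus has the highest number of the three: a 3.1-fold higher number from compound 1 to compound 3 (0.50 log units; beyond the scatter), and a 6.0-fold higher number from compound 2 to compound 3 (0.78 log units; beyond the scatter), both beyond the scatter, while a 1.9-fold lower number from compound 1 to compound 2 (0.28 log units; within the scatter) stays within it.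

Compound 4 `CC(C)(C)c1ccc(C(=O)N2CCC3(CC2)C(=O)N(CC(=O)NCCCCCO)CN3c2ccccc2)cc1` is compound 3 with its chain made one carbon longer: hydroxymethyl in place of hydroxy on a saturated chain carbon, four bonds along the chain from an amide-type nitrogen. Among the measured compounds shown here, none of the measured steps is a lengthening of this kind. The step from compound 1 to compound 3 exchanges a ring-bearing group for an open chain, and the step from compound 2 to compound 3 exchanges a methanesulfonamido group for a 3-hydroxypropyl group, so neither speaks directly to adding one carbon to a chain that already ends in a hydroxy group. For compound 4 the step expected is therefore one within the scatter: a 1.0-fold lower number from compound 3 to compound 4 (0.00 log units; within the scatter). Compound 4 is estimated at 19000 nM in this assay, with a range from 8000 nM to 45000 nM.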

Compound 4, half-maximal inhibitory concentration: 9400 nM
Compound 4: middle estimate off by 2.0-fold (0.31 log units), on the high side, and the stated range covers the measured number.
By their numbers in this assay, from the lowest: compounds 2, 1 and 4 (each within the scatter of the next, the first and the last beyond it); then compound 3.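

In this assay, the first lengthening of a chain that ends in a hydroxy group shows that this position responds to a single added carbon: hydroxymethyl in place of hydroxy, four bonds along the chain from an amide-type nitrogen, gives a modest but real change (a 2.0-fold lower number from compound 3 to compound 4 (0.31 log units; beyond the scatter)). With that carbon, the open chain of compound 4 sits within the scatter of the ring-bearing group of compound 1 (a 1.5-fold higher number from compound 1 to compound 4 (0.19 log units; within the scatter)), whereas the ((methanesulfonamido)methyl)amino group of compound 2 remains clearly apart from it (a 2.9-fold higher number from compound 2 to compound 4 (0.47 log units; beyond the scatter)). Nothing available here explains why one more carbon changes the result at this position.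

Going by these compounds, one step cannot define a trend, so it stays open whether a longer chain, such as a 6-hydroxyhexyl group, would lower the number further, leave it unchanged or raise it again. On these data alone, it also stays open whether the hydroxy group at the chain end matters at all, a question that a chain of the same length ending in an amine or a carboxylic acid would address.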